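A few compounds are considered here, and "the series" means these few. Any claim that something is new, unique, unknown or untested is made for them only; others in the source may bear on it.

Going by the values given here, compound 1 `CCOc1ncc(-c2nc(C(F)(F)F)sc2N2CCN(C(=O)Cn3cnc4cccnc43)[C@H](C)C2)cn1` gives 20 nM in a functional assay on U2OS cells for antagonist activity at C-X-C chemokine receptor type 3 (Homo sapiens), read by beta-arrestin recruitment (a higher number here means a weaker inhibitor, a lower number a stronger inhibitor), and stands lowest of the two numbers measured so far. Compound 2 `COCCOc1ncc(-c2nc(C(F)(F)F)sc2N2CCN(C(=O)Cn3cnc4cccnc43)[C@H](C)C2)cn1` gives 324 nM in this assay. Among the compounds with values here, the single measured step, a 16-fold higher number from compound 1 to compound 2 (1.21 log units; beyond the scatter), concerns the saturated chain two bonds along from the oxygen on the aromatic ring and leaves the rest of the molecule untouched. Compound 3 `CCOc1ncc(-c2nc(C(F)(F)F)sc2N2CCN(C(=O)Cn3nc(C)nc3C)[C@H](C)C2)cn1` keeps that chain as in compound 1 and differs from it elsewhere: a group of 7 heavy atoms (4 carbon, 3 nitrogen; one five-membered aromatic ring with 3 hetero atoms) in place of a group of 9 heavy atoms (6 carbon, 3 nitrogen; one five-membered aromatic ring with 2 hetero atoms, one six-membered aromatic ring with 1 hetero atom), on a saturated chain carbon bound to a carbonyl carbon. Within the data shown here, no measured step touches the saturated chain carbon bound to the carbonyl carbon, so the step from compound 1 to compound 2 bears on compound 3 only as a sign that a single change can move the number by a large amount; it gives no direction for the present change. With the shared core and the remaining substituents unchanged, and a smaller heteroaromatic group entering, the expectation is a modest weakening with wide uncertainty. For compound 3 the expected step is a 4.0-fold higher number from compound 1 to compound 3 (0.60 log units; beyond the scatter). In this assay compound 3 is estimated at 80 nM, with a range from 20 nM to 400 nM.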

Compound 3, half-maximal inhibitory concentration: 173 nM
Compound 3: the middle estimate sits 2.2-fold (0.33 log units) below what was measured; measured number inside the range.
By their numbers in this assay, from the lowest: compound 1; then compounds 3 and 2 (each within the scatter of the next).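

In this assay, the saturated chain carbon bound to a carbonyl carbon proves to be a position that responds to change: the swap to 3,5-dimethyl-1H-1,2,4-triazol-1-yl gives an 8.7-fold higher number from compound 1 to compound 3 (0.94 log units; beyond the scatter). Going by these compounds alone, this is the first reading at this position, since the earlier step concerned only the chain on the oxygen at the other end of the molecule. The group that leaves and the group that enters have the same counts of hydrogen-bond donors and acceptors, so the loss comes with a change that leaves those counts untouched, and the step follows a smaller group with one aromatic ring in place of a larger group with two; no data at hand say which feature of the swap accounts for the step.

With only one replacement at this position, the separate contributions of the two methyl groups, the third ring nitrogen and the lost six-membered ring remain unresolved; an unsubstituted 1,2,4-triazol-1-yl or a benzimidazol-1-yl group would separate them. Also open, going by these compounds, is whether the methoxy step on the ethoxy chain would have the same size on a compound carrying the dimethyltriazole.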